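The compounds below may be only part of what the source reports. "The series", "measured", "known", "first", "only" and "open" are said of these compounds alone.

Measured compounds in an in vitro assay on Sf21 cells for inhibition of high affinity 3',5'-cyclic-AMP phosphodiesterase 7A (Homo sapiens); a lower number here means a stronger inhibitor, a higher number a weaker inhibitor:

Compound 1 `CNc1nc(NC2(C#N)CCCCC2)nc(-n2cncn2)n1` gives > 5000 nM in this assay, a limit of the assay and not a number.
Compound 2 `CNc1nc(NC2(C#N)CCCCC2)nc(OC)n1` gives 521 nM in this assay.
Compound 3 `CNc1nc(Nc2ccccc2)nc(NC2(C#N)CCCCC2)n1` gives > 5000 nM in this assay, again a limit rather than a number.

Compound 3 thus stands at the limit of this assay, shared with compound 1 (the limit of > 5000 nM in this assay, at which 2 of the 3 values shown sit); only compound 2 gives a number, and the step of an at least 9.5-fold higher number from compound 2 to compound 3 (0.98 log units; beyond the scatter) shows that the anilino compound sits well behind the methoxy compound. The step that the two limits leave unreadable from compound 1 to compound 3 cannot be read, as both ends are limits. The step of an at least 9.5-fold lower number from compound 1 to compound 2 (0.98 log units; beyond the scatter) is the only fully readable one and runs from the triazolyl compound to the methoxy compound.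

Compound 4 `CNc1nc(NC2(C#N)CCCCC2)nc(-n2cnc(C#N)n2)n1` is not yet measured. Its change from compound 3 is 3-cyano-1H-1,2,4-triazol-1-yl in place of anilino on an aromatic carbon. The nearest comparison is compound 1, which carries the same triazolyl core group without the nitrile and sits at the limit (the limit of > 5000 nM in this assay, at which 2 of the 3 values shown sit); compound 3, the starting point, sits there too. Among the measured compounds shown here, no measured step shows the effect of the nitrile on the triazolyl group. Compound 4 is therefore expected to remain at or near the limit in this assay, with a step that the limit leaves unreadable from compound 3 to compound 4 expected to be unreadable or small. The estimate for compound 4 is 9000 nM, within 2000 nM to 40000 nM.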

Compound 4, half-maximal inhibitory concentration: > 5000 nM
Compound 4 gave a limit, no number (the forecaster's own chance of this, stated with the estimate: 70%); the middle value is on the limit's open side.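

In this assay, 3-cyano-1H-1,2,4-triazol-1-yl on this aromatic carbon, in place of methoxy, gives an at least 9.5-fold higher number from compound 2 to compound 4 (0.98 log units; beyond the scatter), so a further group at this place falls well behind methoxy. Compound 4 gives > 5000 nM, a limit of the assay and not a number, so adding a nitrile to the triazolyl group does not yield a readable value in this assay. The steps to compound 4 from compound 1 and from compound 3 cannot be read, as both ends of each are limits, and methoxy remains the only group at this place with a number: the limit of > 5000 nM in this assay, at which 3 of the 4 values shown sit.

As far as these compounds go, how compounds 1, 3 and 4 rank among themselves stays open, and so does any effect of the nitrile itself. Compound 2 gives 521 nM. From the compounds shown here alone, it is also open whether ethoxy, a longer alkoxy chain, hydroxyl or dimethylamino at this place would give a number close to that of compound 2 or would join the other compounds at the limit.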